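This account rests on a few compounds, and the source may have more. Where it says the series, first, only, none or still open, it means among the compounds named here.

Measured compounds:
- compound 1, `Cc1c(C(=O)N/N=C\c2c(O)cccc2F)oc2cccc(O)c12`, in a functional assay on MGC-803 cells (Homo sapiens) for inhibition, read by MTT assay (a higher number here means a weaker inhibitor, a lower number a stronger inhibitor), compound 1 gives 10800 nM
- compound 2, `Cc1c(C(=O)N/N=C\c2cc(F)ccc2O)oc2cccc(O)c12`, in this assay compound 2 gives 5230 nM

Within the data shown here, compound 2 stands with the lowest of the two numbers so far; its nearest neighbour is compound 1, and the step of a 2.1-fold lower number from compound 1 to compound 2 (0.31 log units; beyond the scatter) separates them. Both share the same core and differ only in the aryl group on the carbon with a double bond to nitrogen.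

Compound 3, `Cc1c(C(=O)N/N=C\c2ccc(O)cc2O)oc2cccc(O)c12`, has not been measured in this assay. It differs from compound 2 by 2,4-dihydroxyphenyl in place of 5-fluoro-2-hydroxyphenyl on a carbon with a double bond to nitrogen. Among the measured compounds shown here, the only measured step, from compound 1 to compound 2, concerns a change of positions of a fluorine and a hydroxyl within the same aryl group, and was modest; no measured pair shows a fluorine replaced by a hydroxyl, so nothing among the measured data speaks directly to this change. A step within the scatter, or at most a modest one in either direction, is therefore expected in this assay for compound 3. On that basis compound 3 is estimated at 5500 nM, with a range from 2200 nM to 14000 nM, which corresponds to an expected step of a 1.1-fold higher number from compound 2 to compound 3 (0.02 log units; within the scatter).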

Compound 3, half-maximal inhibitory concentration: 7330 nM
For compound 3 the middle estimate is 1.3-fold (0.12 log units) below the measured one; low and high end bracket the measured number.
By their numbers in this assay, from the lowest: compounds 2, 3 and 1 (each within the scatter of the next, the first and the last beyond it).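

In this assay, 2,4-dihydroxyphenyl on the carbon with a double bond to nitrogen gives a 1.4-fold higher number from compound 2 to compound 3 (0.15 log units; within the scatter), and against the other fluorinated aryl group it gives a 1.5-fold lower number from compound 1 to compound 3 (0.17 log units; within the scatter). Compound 3 carries no fluorine on this aryl group and still lies within the scatter of both fluorinated compounds, so among these three compounds fluorine on this aryl group is not required for a number in this range, and a second hydroxyl in its place brings no step beyond the scatter. The one separation beyond the scatter remains a 2.1-fold lower number from compound 1 to compound 2 (0.31 log units; beyond the scatter), with compound 3 unresolved from either end, and no measurement on hand accounts for any of these steps.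

Every aryl group shown carries at least one hydroxyl, so the compounds leave open what this place tolerates without one, for instance with a methoxy group, an amine or a carboxylic acid on the aryl group. On these data alone, the shared core is also the same throughout, so the contribution of its methyl and hydroxyl groups to these numbers remains open.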